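This account rests on a few compounds, and the source may have more. Where it says the series, first, only, none or still open, it means among the compounds named here.

Working notes on the series in an assay on HEK293 cells for inhibition of Voltage-dependent T-type calcium channel subunit alpha-1G (Homo sapiens), read by patch clamp; on this read-out lower numbers stand for stronger inhibition and higher numbers for weaker inhibition.

Compound 1 `CCCc1nc(-c2ccccc2)c(CNCCN2CCN(c3ccc(Cl)cc3)CC2)o1` gives 2820 nM and has the lowest number of the three measured compounds. Compound 2 `CCCc1nc(-c2ccccc2)c(CNCCCN2CCN(c3ccc(C(F)(F)F)cc3)CC2)o1` gives 7250 nM; the gap between compound 1 and compound 2 is beyond the scatter, but the two differ in more than one place, so the pair shows only what its two values show. Compound 3 `CCCc1nc(-c2ccccc2)c(CNCCCN2CCN(c3ccc(C)cc3)CC2)o1` gives 130000 nM, the highest number in the set.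

Among the compounds with values here, the one single-point step that is available is an 18-fold higher number from compound 2 to compound 3 (1.25 log units; beyond the scatter). It concerns a change of the group on the aromatic carbon of the phenyl attached to the ring nitrogen, not a change of where that group sits, so it does not bear directly on the step to compound 4.

Compound 4 `CCCc1nc(-c2ccccc2)c(CNCCN2CCN(c3cccc(Cl)c3)CC2)o1` differs from compound 1 by 3-chlorophenyl in place of 4-chlorophenyl on an amine nitrogen in a ring. Within the data shown here, no measured pair in this set moves the chlorine within the phenyl while leaving the rest untouched, so there is no comparable step to lean on. The expectation is therefore no step beyond the scatter, with wide uncertainty: the step from compound 1 to compound 4 is estimated as a 1.2-fold higher number from compound 1 to compound 4 (0.09 log units; within the scatter). For compound 4 the expected value in this assay is 3500 nM, with a range from 1000 nM to 12000 nM.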

Compound 4, half-maximal inhibitory concentration: 1450 nM
The estimate for compound 4 lay 2.4-fold (0.38 log units) above the measured number, within the range that was stated.
By their numbers in this assay, from the lowest: compounds 4 and 1 (each within the scatter of the next); then compound 2; then compound 3.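

In this assay, 3-chlorophenyl in place of 4-chlorophenyl on an amine nitrogen in a ring gives a 1.9-fold lower number from compound 1 to compound 4 (0.29 log units; within the scatter), so the two chlorine placements on this phenyl cannot be told apart in this read-out. Within the data shown here, this is the first step that keeps the same atoms and changes only where the chlorine sits, whereas the only earlier single-point step, an 18-fold higher number from compound 2 to compound 3 (1.25 log units; beyond the scatter), exchanged one group for another on compounds with a longer chain and lay beyond the scatter. No measurement on hand accounts for the closeness of compound 1 and compound 4.

Still open, as far as these compounds go, is whether a methoxy group or a nitrile on the same phenyl would give numbers close to those of the two chlorophenyl compounds, and whether trifluoromethyl and methyl would also stay within the scatter when moved as the chlorine was. From the compounds shown here alone, it is also open whether 3-chlorophenyl on the longer chain of compound 2 and compound 3 would give the same picture, since compound 4 and compound 1 cover only the shorter chain.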